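Notes on a methylphenyl swap in a small analgesic series

The compounds below may be only part of what the source reports. "The series", "measured", "known", "first", "only" and "open" are said of these compounds alone.

Measured values in a functional assay on the whole organism (strain Kunming) for inhibition, with Mus musculus as the target, in the writhing test, with stated times of 1 h and 15 min, at a dose of 200 mg/kg by the oral route; on this read-out lower numbers stand for less inhibition and higher numbers for more inhibition at the one dose given (going by the name of the read-out):
compound 1 `Cc1ccc(N(C)CC2CCC/C(=C\c3ccccc3)C2=O)cc1` gives 81%
compound 2 `Cc1cccc(N(C)CC2CCC/C(=C\c3ccccc3)C2=O)c1` gives 76.7%
compound 3 `Cc1ccc(N(C)CC2CCC/C(=C\c3ccccc3)C2(O)c2ccccc2)cc1` gives 64.2%

Compound 1 and compound 2 share a core and differ only by 3-methylphenyl in place of 4-methylphenyl on an amine nitrogen. The step of a number 4.3 percentage points lower from compound 1 to compound 2 (within the scatter) is within the scatter, so the two values are not ordered against each other. Compound 3 carries a different core; the difference between the core of compound 1 and the core of compound 3 is not broken down here. In this assay compound 3 stands lowest of the three, beyond the scatter from both compound 1 and compound 2.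

Compound 4 `Cc1cccc(N(C)CC2CCC/C(=C\c3ccccc3)C2(O)c2ccccc2)c1` has not yet been measured. It differs from compound 3 by 3-methylphenyl in place of 4-methylphenyl on an amine nitrogen, the same change as that from compound 1 to compound 2, made at the same place. Because the measured step of a number 4.3 percentage points lower from compound 1 to compound 2 (within the scatter) is within the scatter, the step of a number 4.2 percentage points lower from compound 3 to compound 4 (within the scatter) is expected to be small as well, with compound 4 expected to stay close to compound 3 and clearly under compound 1 and compound 2. The estimate for compound 4 is 60%, expected to fall between 48% and 72%.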

Compound 4, a percentage reported as inhibition, in the whole organism at one dose (the size of the read-out at that dose, not a potency): 70.6%
Estimate against measurement, compound 4: 10.6 percentage points below, and the stated range covers the measured number.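

On the second core, 3-methylphenyl in place of 4-methylphenyl on an amine nitrogen gives a number 6.4 percentage points higher from compound 3 to compound 4 (within the scatter) in this assay. Set beside the step on the first core, the change reads the same on both cores within what this read-out can resolve: the same change on two cores in this assay, a number 4.3 percentage points lower (within the scatter) from compound 1 to compound 2 and a number 6.4 percentage points higher (within the scatter) from compound 3 to compound 4, 10.7 percentage points apart, within the scatter of two such steps. This shows that in these two pairs the swap stays inside the scatter on either core, but it does not show that the swap is without effect in general, and no reversal between the cores can be read from the two steps, which rest on two pairs at a single dose.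

The compounds shown leave open how the series responds when the methylphenyl on the amine nitrogen gives way to an unsubstituted phenyl or a methoxyphenyl, or when the methyl on that nitrogen gives way to a longer chain. They also leave open whether the two methylphenyl isomers would stay together across a range of doses or on any third core.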